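This account rests on a few compounds, and the source may have more. Where it says the series, first, only, none or still open, it means among the compounds named here.

Compound 1 `O=C1OC(c2ccc(OCc3ccccc3)cc2)C(c2ccc(F)cc2)=C1O` belongs to this set, and in an assay on blood for inhibition of Polyunsaturated fatty acid 5-lipoxygenase (Homo sapiens), tested at 100 uM (a higher number here means a stronger effect of the compound at the concentration tested, a lower number a weaker effect), compound 1 gives "not determined" (no result reported). Going by the values given here, compound 2 `O=C1OC(c2ccc(O)cc2)C(c2ccc(O)cc2)=C1O` is therefore the only compound with a number: in this assay compound 2 gives 27.8%. Compound 3 `O=C1OC(c2ccc(O)cc2)C(c2ccc(F)cc2)=C1O` is still to be measured. The difference lies in a single position: fluoro in place of hydroxy on an aromatic carbon. Among the compounds with values here, no measured pair shows what such a swap of hydroxy for fluoro on an aromatic carbon does here, so the expected step of a number 3.8 percentage points lower from compound 2 to compound 3 (within the scatter) is held small, if anything a slight loss, and no larger than the usual scatter. Compound 3 is thus estimated at 24% in this assay, within a range from 5% to 48%.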

Compound 3, a percentage reported as activity, at one concentration (the size of the read-out at that concentration, not a potency): 0%
For compound 3 the middle estimate is 24 percentage points above the measured one, outside the stated range (below it).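

In this assay, fluoro in place of hydroxy on this aromatic carbon gives a number 27.8 percentage points lower from compound 2 to compound 3 (beyond the scatter), so this position is not indifferent to the change, and the read-out of compound 2 does not survive it. Compound 3 still carries one 4-hydroxyphenyl group, and that group alone leaves compound 3 at 0%. Nothing at hand explains the loss. Going by these compounds, whether a methoxy group or an amine at this position would keep any of the read-out stays open, as does the part played by the remaining hydroxy.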